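Working notes: from compound 3 to compound 4

A few compounds are considered here, and "the series" means these few. Any claim that something is new, unique, unknown or untested is made for them only; others in the source may bear on it.

Measured so far in a functional assay on the whole organism (plasma, strain Wistar) with Rattus norvegicus as the target, with a stated time of 15 days, at a dose of 30 mg/kg by the oral route; a lower number here means a weaker effect, a higher number a stronger effect of the compound at the dose given:
- compound 1 `O=C1NC(=O)/C(=C/c2ccc(OCCSc3nnc(-c4ccccc4)[nH]3)cc2)S1`: 14.7%
- compound 2 `O=C1NC(=O)/C(=C/c2ccc(OCCSc3nnc(-c4ccc([N+](=O)[O-])cc4)[nH]3)cc2)S1`: 16%
- compound 3 `O=C1NC(=O)/C(=C/c2ccc(OCCSc3nnc(-c4ccccc4[N+](=O)[O-])[nH]3)cc2)S1`: 20.1%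

Compound 3 holds the highest of the three numbers, but neither a number 5.4 percentage points higher from compound 1 to compound 3 (within the scatter) nor a number 4.1 percentage points higher from compound 2 to compound 3 (within the scatter) leaves the scatter, so the three compounds cannot be ranked.

Compound 4 `O=C1NC(=O)/C(=C/c2ccc(OCCSc3nnc(-c4ccc(Cl)cc4)[nH]3)cc2)S1` has not yet been tested. It differs from compound 3 as follows: 4-chlorophenyl in place of 2-nitrophenyl on an aromatic carbon. Among the compounds with values here, no measured step exchanges a nitrophenyl for a chlorophenyl. Within the data shown here, the steps that bear on the case are those that put a nitro onto the phenyl, a number 1.3 percentage points higher from compound 1 to compound 2 (within the scatter) and a number 5.4 percentage points higher from compound 1 to compound 3 (within the scatter), both within the scatter. A step within the scatter is therefore expected, a number 4.1 percentage points lower from compound 3 to compound 4 (within the scatter). For compound 4 the estimate in this assay is 16%, with a range from 8% to 25%.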

Compound 4, a percentage reported as activity, at one dose (the size of the read-out at that dose, not a potency): 23.7%
For compound 4 the middle estimate is 7.7 percentage points below the measured one; measured number inside the range.
By their numbers in this assay, from the lowest: compounds 1, 2, 3 and 4 (each within the scatter of the next).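

In this assay, 4-chlorophenyl on the aromatic carbon between two ring nitrogen atoms adds a halogen to the phenyl and nitrophenyl groups, yet all three new steps remain within the scatter: a number 3.6 percentage points higher from compound 3 to compound 4 (within the scatter), a number 7.7 percentage points higher from compound 2 to compound 4 (within the scatter) and a number 9 percentage points higher from compound 1 to compound 4 (within the scatter). Chloro in place of either nitro or hydrogen therefore does not separate compound 4 from the earlier compounds. No available measurement accounts for these numbers.

Going by these compounds, whether an amine or a carboxylic acid on the phenyl would give a step beyond the scatter remains open.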